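A few compounds are considered here, and "the series" means these few. Any claim that something is new, unique, unknown or untested is made for them only; others in the source may bear on it.

Measured in a physicochemical assay for solubility, read by nephelometry; a higher number here means a more soluble compound, a lower number a less soluble compound:
Compound 1 `CC1(C)C(=O)N(c2ccc(SC(F)(F)F)cc2)C(=O)N1Cc1ccnc(C(=O)O)c1` gives 0.142 ug/mL
Compound 2 `COc1ccc(CNc2cc(CN3C(=O)N(c4ccc(SC(F)(F)F)cc4)C(=O)C3(C)C)ccn2)cc1` gives < 0.027 ug/mL

Compound 2 has a limit of the assay rather than a number, and stands at the limit of < 0.027 ug/mL in this assay, at which 1 of the 2 values shown sits. Compound 3 `CC1(C)C(=O)N(c2ccc(SC(F)(F)F)cc2)C(=O)N1Cc1ccnc(NCc2ccccc2)c1` carries hydrogen in place of methoxy on an aromatic carbon, so 4-methoxybenzyl becomes benzyl (hydrogen in place of methoxy on an aromatic carbon). Among the measured compounds shown here, the only measured step, an at least 5.2-fold lower number from compound 1 to compound 2 (0.72 log units; beyond the scatter), exchanged carboxy for the whole (4-methoxybenzyl)amino and does not isolate the methoxy, so no step beyond the scatter is expected in this assay. The estimate therefore means a step that the limit leaves unreadable from compound 2 to compound 3. Compound 3 is expected at 0.025 ug/mL, within an estimated range of 0.01 ug/mL to 0.07 ug/mL.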

Compound 3, solubility: < 0.026 ug/mL
Compound 3: only a limit was reported; the forecaster's own chance of this, stated with the estimate: 70%; the middle value does not contradict the limit.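

In this assay compound 3 gives < 0.026 ug/mL, which is a limit of the assay and not a number. Compound 2 also sits at a limit, so the step that removes the methoxy cannot be read: the limit of < 0.027 ug/mL in this assay, at which 1 of the 3 values shown sits.

What is new is that benzylamino, without the methoxy, still gives an at least 5.4-fold lower number from compound 1 to compound 3 (0.73 log units; beyond the scatter).

Going by these compounds, what the methoxy itself contributes stays open. So does whether a hydroxy or dimethylamino group on that aromatic carbon would give a reading clear of the limit.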